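Removing the Aryl Methyl from the Amide of Compound 3

A few compounds are considered here, and "the series" means these few. Any claim that something is new, unique, unknown or untested is made for them only; others in the source may bear on it.

Measured in a functional assay on QGY7701 cells (Homo sapiens) for cytotoxicity, read by MTT assay, with a stated time of 24 h; a lower number here means a stronger inhibitor, a higher number a weaker inhibitor:
compound 1 `C=CC1=C(C(=O)NCC(C)C)C(c2ccc(F)cc2)OC1` gives > 100000 nM, which is a limit of the assay and not a number.
compound 2 `C=CC1=C(C(=O)Nc2ccccc2)C(c2ccc(Cl)c(Cl)c2)OC1` gives > 100000 nM, again a limit rather than a number.
compound 3 `C=CC1=C(C(=O)Nc2ccc(C)cc2)C(c2ccc(F)cc2)OC1` gives 59200 nM.

Going by the values given here, compound 3 therefore stands alone: it holds the only number in this assay, while the other two values sit at the limit (the limit of > 100000 nM in this assay, at which 2 of the 3 values shown sit). The one measured step that connects two of these compounds is an at least 1.6-fold lower number from compound 1 to compound 3 (0.22 log units; that floor lies within the scatter), and its floor lies within the usual scatter, so it gives no firm direction.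

Compound 4 `C=CC1=C(C(=O)Nc2ccccc2)C(c2ccc(F)cc2)OC1` differs from compound 3 by hydrogen in place of methyl on an aromatic carbon. Among the compounds with values here, no measured step covers this exact change; the step from compound 1 to compound 3 alters the whole amide substituent and only shows that a 4-methylphenyl amide reaches a number where an isobutyl amide does not. Compound 2, which carries an unsubstituted phenyl on the amide nitrogen together with a different aryl group on the core, gives only a limit.

On this evidence compound 4 is expected to lose little or nothing beyond the scatter, with a real chance that it falls back to the limit: an estimated step of a 1.5-fold higher number from compound 3 to compound 4 (0.18 log units; within the scatter). Compound 4 is thus estimated at 90000 nM, within 40000 nM to 200000 nM.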

Compound 4, half-maximal inhibitory concentration: 46700 nM
Compound 4: middle estimate off by 1.9-fold (0.28 log units), on the high side, within the range that was stated.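

In this assay, the methyl on this aromatic carbon, para to a large group, turns out not to be needed for a measurable number, since its replacement by hydrogen stays within the scatter: a 1.3-fold lower number from compound 3 to compound 4 (0.10 log units; within the scatter). The plain phenyl amide also gives the first step from the isobutyl amide that clears the scatter, an at least 2.1-fold lower number from compound 1 to compound 4 (0.33 log units; beyond the scatter), and with this amide held constant, the group on the saturated ring carbon also counts, as 4-fluorophenyl in place of 3,4-dichlorophenyl gives an at least 2.1-fold lower number from compound 2 to compound 4 (0.33 log units; beyond the scatter). Both of these steps are floors and not measured sizes, as each starts from a value that is a limit of the assay and not a number: the limit of > 100000 nM in this assay, at which 2 of the 4 values shown sit.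

What an amine, a carboxylic acid or a longer chain would do on this aromatic carbon stays open, so the compounds shown describe this position only through hydrogen and methyl. As far as these compounds go, it also stays open how far the true steps from the isobutyl amide and from the 3,4-dichlorophenyl group extend, and whether 4-methylphenyl and phenyl would still match on a different group at the saturated ring carbon.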